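The source may report more compounds than this note shows. Statements on the series, on what has been measured and on what is new or still open speak of the compounds shown alone.

The measured compounds, one after another: compound 1 `Cc1ccc(C)c(NC(=O)CSc2nnc(-c3ccoc3C)n2Cc2ccco2)c1`; compound 2 `COc1ccc(C)cc1NC(=O)CSc1nnc(-c2ccoc2C)n1Cc1ccco1`; compound 3 `Cc1occc1-c1nnc(SCC(=O)Nc2cccc(F)c2)n1Cc1ccco1`. In a functional assay on CHO cells for antagonist activity at Orexin/Hypocretin receptor type 1 (Homo sapiens), read by FLIPR and calcium flux (a higher number here means a weaker inhibitor, a lower number a stronger inhibitor), compound 1 gives > 15800 nM, which is a limit of the assay rather than a number. In this assay compound 2 gives 2510 nM. Compound 3 gives > 15800 nM in this assay, again a limit of the assay and not a number.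

Compound 3 therefore stands at the limit (the limit of > 15800 nM in this assay, at which 2 of the 3 values shown sit), together with compound 1, and only compound 2 has a measured number among the three. The unmeasured compound 4 `CC(=O)c1ccc(NC(=O)CSc2nnc(-c3ccoc3C)n2Cc2ccco2)cc1` differs from compound 3 in one place: 4-acetylphenyl in place of 3-fluorophenyl on an amide-type nitrogen.

Going by the values given here, two measured steps bear on this change. The step that the two limits leave unreadable from compound 1 to compound 3 cannot be read, as both ends sit at the limit. The step of an at least 6.2-fold higher number from compound 2 to compound 3 (0.79 log units; beyond the scatter) shows that the phenyl ring on the amide nitrogen can move the number by a readable amount, and an at least 6.2-fold lower number from compound 1 to compound 2 (0.79 log units; beyond the scatter) shows that an oxygen-bearing substituent on that ring went with a lower number than a methyl. The change to compound 4 brings an oxygen-bearing group of a different kind, so the direction in this assay is uncertain. Compound 4 is expected to come in at 9000 nM, within 2500 nM to 30000 nM, an estimated step of an at least 1.7-fold lower number from compound 3 to compound 4 (0.24 log units; that floor lies within the scatter) that may well leave compound 4 at the limit as well.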

Compound 4, inhibition constant: 2510 nM
Beside the measured number, compound 4's estimate is 3.6-fold (0.55 log units) above it, within the range that was stated.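

In this assay, 4-acetylphenyl on the amide-type nitrogen gives an at least 6.2-fold lower number from compound 3 to compound 4 (0.79 log units; beyond the scatter) and an at least 6.2-fold lower number from compound 1 to compound 4 (0.79 log units; beyond the scatter), so a readable number at this position does not depend on the 2-methoxy-5-methylphenyl group. Set against that group directly, 4-acetylphenyl gives no change at the digits printed from compound 2 to compound 4 (within the scatter), which shows that two rings with different substituents and different substitution patterns can sit at the same level here. Among these four compounds, the two rings carrying an oxygen-bearing group give numbers, and none goes against this pattern, while the rings with only methyl or fluorine stay at a limit of the assay, which is not a number: the limit of > 15800 nM in this assay, at which 2 of the 4 values shown sit.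

Going by these compounds, the steps out of that limit are floors, so their true size stays open, and the four compounds do not separate the carbonyl oxygen of the acetyl group from the rest of that group or from its place on the ring. Also open, on these data alone, is whether a nitrile, an amine or a carboxylic acid in place of the acetyl group would go with a lower number, a higher one or the same.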